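The compounds below may be only part of what the source reports. "The series", "measured", "known", "first", "only" and "open" are said of these compounds alone.

Compound 3 `COc1cc(Cl)cc(-c2nn(-c3cccc(NC(=O)Nc4ccc(Cl)c(Cl)c4)c3)cc2-c2ccncc2)c1` gives -3% in a functional assay on NCI/ADR-RES cells (Homo sapiens) for inhibition, read by sulforhodamine B assay, with a stated time of 48 h, tested at 100 uM; a lower number here means a stronger effect, a higher number a weaker effect of the compound at the concentration tested. It lies within the scatter of compound 2 `O=C(Nc1cccc(-n2cc(-c3ccncc3)c(-c3cc(O)cc(Cl)c3)n2)c1)Nc1ccc(Cl)c(Cl)c1`, which gives 2%. Compound 1 `O=C(Nc1cccc(-n2cc(-c3ccncc3)c(-c3cc(O)cc(Cl)c3)n2)c1)Nc1ccc(Cl)c(C(F)(F)F)c1` gives -15%, and compound 3 stands higher than compound 1, beyond the scatter. Compound 4 `COc1cc(Cl)cc(-c2nn(-c3cccc(NC(=O)c4cccc(C(F)(F)F)c4)c3)cc2-c2ccncc2)c1` differs from compound 3 by 3-(trifluoromethyl)phenyl in place of (3,4-dichlorophenyl)amino on a carbonyl carbon. Of the measured steps, a number 17 percentage points higher from compound 1 to compound 2 (beyond the scatter) concerns the same kind of exchange between chloro and trifluoromethyl, though on a urea that compound 4 no longer carries; a number 5 percentage points lower from compound 2 to compound 3 (within the scatter) lies elsewhere and was small. Among the compounds with values here, no measured step covers the loss of the amino-bearing linker, so the direction is open; the step of a number 2 percentage points lower from compound 3 to compound 4 (within the scatter) is expected to stay within the scatter. Compound 4 is estimated at -5%, between -25% and 15%.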

Compound 4, a percentage reported as activity, at one concentration (the size of the read-out at that concentration, not a potency): 31%
Beside the measured number, compound 4's estimate is 36 percentage points below it; measured number above the stated range.
By their numbers in this assay, from the lowest: compound 1; then compounds 3 and 2 (each within the scatter of the next); then compound 4.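

In this assay the carbonyl carbon position is sensitive, with a number 34 percentage points higher from compound 3 to compound 4 (beyond the scatter), a weaker effect and a larger step than those seen earlier at the chloro or the phenol oxygen. The change removes the amino group and its hydrogen-bond donor while also replacing the ring substituents, so these two parts cannot be separated here. No evidence available explains the shift.

Which part carries the loss stays open. Also open, going by these compounds, is how 3,4-dichlorophenyl directly on the carbonyl carbon, or morpholine in place of the aryl group, would read.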